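Lengthening the Alkoxy Chain by One More Carbon

A few compounds are considered here, and "the series" means these few. Any claim that something is new, unique, unknown or untested is made for them only; others in the source may bear on it.

Compound 3 `CCCCCCCCCCOc1ccc(-c2c(C)[nH]c(=O)n2C)cc1` gives the lowest number of the three measured compounds in a functional assay on the whole organism with Rattus norvegicus as the target (on this read-out lower numbers stand for an effect already at smaller amounts and higher numbers for an effect only at larger amounts of compound), at 0.1 mg/kg. Its nearest neighbour is compound 1 `CCCCOc1ccc(-c2c(C)[nH]c(=O)n2C)cc1`, which in this assay gives 0.3 mg/kg; compound 2 `CCCCCCCCOc1ccc(-c2c(C)[nH]c(=O)n2C)cc1` lies furthest away, with 30 mg/kg in this assay. Compound 4 `CCCCCCCCCCCOc1ccc(-c2c(C)[nH]c(=O)n2C)cc1` differs from compound 3 by methyl in place of hydrogen on a saturated chain carbon, ten or more bonds along the chain from an oxygen on an aromatic ring.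

The measured steps all concern the same chain, but each adds several carbons at once: a 100-fold higher number from compound 1 to compound 2 (2.00 log units; beyond the scatter), a 300-fold lower number from compound 2 to compound 3 (2.48 log units; beyond the scatter) and a 3.0-fold lower number from compound 1 to compound 3 (0.48 log units; beyond the scatter). Going by the values given here, the series is not monotonic, so these steps give no clear direction for a single added carbon, and no step of exactly this size has been measured. The two large steps show that chain length can move the number a long way in either direction, which widens the range rather than pointing it.

Compound 4 is therefore expected to stay close to compound 3, with a 2.0-fold higher number from compound 3 to compound 4 (0.30 log units; within the scatter), and its estimated value is 0.2 mg/kg, within a range from 0.05 mg/kg to 2 mg/kg.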

Compound 4, minimum effective dose: 0.1 mg/kg
For compound 4 the middle estimate is 2.0-fold (0.30 log units) above the measured one; measured number inside the range.
By their numbers in this assay, from the lowest: compounds 3 and 4 (each within the scatter of the next); then compound 1; then compound 2.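

In this assay, methyl in place of hydrogen on a saturated chain carbon, ten or more bonds along the chain from an oxygen on an aromatic ring, leaves the number unmoved (no change at the digits printed from compound 3 to compound 4 (within the scatter)). Going by these compounds alone, this is the first single-carbon step, as the earlier steps each added several carbons, and at this place it shows no measurable effect. Within the data shown here, compound 4 also relates to the other two as compound 3 does (a 300-fold lower number from compound 2 to compound 4 (2.48 log units; beyond the scatter); a 3.0-fold lower number from compound 1 to compound 4 (0.48 log units; beyond the scatter)), so compound 2 remains the only compound with a high number.

Going by these compounds, whether a longer chain, or an amine or a carboxylic acid on the chain, would keep the number at this level stays open. No measurement is available that accounts for the position of compound 2 among these chains.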